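The compounds below may be only part of what the source reports. "The series", "measured", "known", "first", "only" and "open" are said of these compounds alone.

Among the three compounds measured so far, compound 3 `Cc1nn(-c2nc(-c3ccc(Cl)c(Cl)c3)c(SC(C)C)s2)c(C(=O)O)c1-c1ccc(Cl)cc1` stands second highest in a functional assay on BJAB cells (Homo sapiens) for antiproliferative activity, with a stated time of 4 days (on this read-out higher numbers stand for an effect only at larger amounts of compound and lower numbers for an effect already at smaller amounts), giving 2500 nM. Its nearest neighbour is compound 1 `Cc1ccc(-c2c(C)nn(-c3nc(-c4ccc(Cl)c(Cl)c4)c(SC(C)C)s3)c2C(=O)O)cc1`, which gives 3800 nM; the step of a 1.5-fold lower number from compound 1 to compound 3 (0.18 log units; within the scatter) is within the scatter. The furthest is compound 2 `Cc1nn(-c2nc(-c3ccc(Cl)c(Cl)c3)c(SC(C)C)s2)c(C(=O)O)c1-c1cccc(F)c1`, which gives 900 nM; the step of a 2.8-fold higher number from compound 2 to compound 3 (0.44 log units; beyond the scatter) is beyond the scatter, as is a 4.2-fold lower number from compound 1 to compound 2 (0.63 log units; beyond the scatter).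

Compound 4 `Cc1cc(C#N)cc(-c2c(C)nn(-c3nc(-c4ccc(Cl)c(Cl)c4)c(SC(C)C)s3)c2C(=O)O)c1` is the next member. The change from compound 3 is 3-cyano-5-methylphenyl in place of 4-chlorophenyl on an aromatic carbon. All three measured steps also exchange the aryl group at this same position of the shared core, so each of them bears on the move to compound 4. They show that swapping one aryl for another here shifts this assay by modest amounts in either direction, with the 3-fluorophenyl of compound 2 giving the lowest number seen. Going by the values given here, no measured compound carries a nitrile or a 3,5-disubstituted aryl, so the direction for compound 4 is not fixed by precedent. Compound 4 is therefore expected to land near the measured range, with an estimated step of a 1.7-fold lower number from compound 3 to compound 4 (0.22 log units; within the scatter) from compound 3. The estimate for compound 4 is 1500 nM, with a range from 500 nM to 5000 nM.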

Compound 4, half-maximal effective concentration: 4800 nM
The estimate for compound 4 lay 3.2-fold (0.51 log units) below the measured number; the measured number falls inside the stated range.
By their numbers in this assay, from the lowest: compound 2; then compounds 3, 1 and 4 (each within the scatter of the next).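

In this assay, compound 4 is the only compound shown with a nitrile on the aryl group at this position, and its number cannot be told apart from those of its two nearest neighbours: the change shows a 1.9-fold higher number from compound 3 to compound 4 (0.28 log units; within the scatter), and a 1.3-fold higher number from compound 1 to compound 4 (0.10 log units; within the scatter). The one clear separation is from the 3-fluorophenyl group, with a 5.3-fold higher number from compound 2 to compound 4 (0.73 log units; beyond the scatter), the largest step among the four compounds. Going by these compounds alone, three different aryl groups, 4-methylphenyl, 4-chlorophenyl and 3-cyano-5-methylphenyl, therefore read alike at this position of the shared core, and compound 2 is the one compound that goes against this. Nothing available explains why compound 2 stands apart from the other three.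

The compounds shown leave open what the nitrile and the methyl of compound 4 each contribute, as neither appears alone on a phenyl ring in a way that isolates it from the other. Also open, going by these compounds, is how this position would respond to a phenyl ring carrying an amine or a methoxy group, or to a cyclohexyl group in place of the aryl.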